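Methoxy for Hydroxy on a Glutathione Transferase Inhibitor Scaffold

A few compounds are considered here, and "the series" means these few. Any claim that something is new, unique, unknown or untested is made for them only; others in the source may bear on it.

Compound 1 `CO[C@H]1C=C(COC(C)=O)C(=O)[C@@H]2O[C@@](C)(OC)[C@](C)(OC)O[C@@H]12`: "not determined" (no result reported)
Compound 2 `CO[C@]1(C)O[C@H]2[C@H](O)C=C(COC(C)=O)C(=O)[C@@H]2O[C@@]1(C)OC`: > 100000 nM

For the measured compounds named here, compound 1 has no reported result; compound 2 is the only compound with a reading, and that reading is a limit of the assay rather than a number. In an assay on isolated protein for inhibition of glutathione S-transferase A2 (Homo sapiens), read by spectrophotometry, with a stated time of 3 min (on this read-out higher numbers stand for weaker inhibition and lower numbers for stronger inhibition), compound 2 gives > 100000 nM, which is the limit (the limit of > 100000 nM in this assay, at which 1 of the 2 values shown sits). Compound 3 `CO[C@@H]1C=C(COC(C)=O)C(=O)[C@@H]2O[C@@](C)(OC)[C@](C)(OC)O[C@@H]12` differs from compound 2 by methyl in place of hydrogen on an oxygen on a saturated carbon. Going by the values given here, with no measured step to draw on, the expected change from compound 2 to compound 3 is a step that the limit leaves unreadable from compound 2 to compound 3, none beyond the scatter. Compound 3 is therefore estimated at 150000 nM, between 30000 nM and 1000000 nM.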

Compound 3, half-maximal inhibitory concentration: > 100000 nM
Compound 3 gave a limit, no number (the forecaster's own chance of this, stated with the estimate: 80%); the middle value is on the limit's open side.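

No step from compound 2 to compound 3 can be read in this assay, as both readings are limits: the limit of > 100000 nM in this assay, at which 2 of the 3 values shown sit.

The compounds shown leave open how strongly compound 2 and compound 3 inhibit, and whether hydroxy to methoxy changes inhibition at all.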